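The source may hold more compounds than are shown below. What is called first, only, known or untested is meant among the compounds shown, and "the series" means these compounds.

In a functional assay on MGC-803 cells (Homo sapiens) for inhibition, read by MTT assay, with a stated time of 48 h (on this read-out higher numbers stand for weaker inhibition and lower numbers for stronger inhibition), compound 1 (`COc1ccc(-c2coc3cc(OCCCSC(=S)N4CCN(C)CC4)ccc3c2=O)cc1`) gives 21900 nM, level with compound 2 (`COc1ccc(-c2coc3cc(OCCCSC(=S)N4CCN(C(C)=O)CC4)ccc3c2=O)cc1`) at 39400 nM, while compound 3 (`COc1ccc(-c2coc3cc(OCCCSC(=S)N4CCN(C(=O)OC(C)(C)C)CC4)ccc3c2=O)cc1`) gives 6070 nM. Compound 4 (`COc1ccc(-c2coc3cc(OCCCCCBr)ccc3c2=O)cc1`) carries this change: a group of 3 heavy atoms (2 carbon, 1 bromine; no ring) in place of a group of 10 heavy atoms (6 carbon, 2 nitrogen, 2 sulfur; one six-membered non-aromatic ring with 2 hetero atoms), on a saturated chain carbon, three bonds along the chain from an oxygen on an aromatic ring. Among the measured compounds shown here, the only measured steps nearby are substitutions on the amine nitrogen in the ring: a 1.8-fold higher number from compound 1 to compound 2 (0.26 log units; within the scatter), a 3.6-fold lower number from compound 1 to compound 3 (0.56 log units; beyond the scatter) and a 6.5-fold lower number from compound 2 to compound 3 (0.81 log units; beyond the scatter). For the measured compounds named here, they bear only loosely on compound 4, as none removes that ring, and no measured compound lacks it. No step beyond the scatter is therefore expected in this assay, though confidence is low. The estimated step is a 1.4-fold higher number from compound 1 to compound 4 (0.14 log units; within the scatter). For compound 4, the expected value is 30000 nM, with an estimated range of 10000 nM to 80000 nM.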

Compound 4, half-maximal inhibitory concentration: > 100000 nM
Compound 4: no number, only a limit (the forecaster's own chance of this, stated with the estimate: 20%); at least 3.3-fold (0.52 log units) between middle value and limit.
By their numbers in this assay, from the lowest: compound 3; then compounds 1 and 2 (each within the scatter of the next). At a limit, above all of these: compound 4.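

Compound 4 is a limit, not a number, in this assay: > 100000 nM. With 2-bromoethyl in place of the group holding the six-membered non-aromatic ring, the result is an at least 4.5-fold higher number from compound 1 to compound 4 (0.65 log units; beyond the scatter). Compounds 1 to 3 all keep that ring and vary only its amine nitrogen, so this is the first sign that removing the whole group moves the read-out beyond the scatter, with the true size of the step unknown: the limit of > 100000 nM in this assay, at which 1 of the 4 values shown sits.

The compounds shown do not separate the loss of the ring from the loss of the two sulfur atoms. From the compounds shown here alone, how a dimethylamino group, a carboxylic acid or a longer chain would read in this place remains open.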